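Bromo to hydroxy on the aryl group of compound 2

The source may hold more compounds than are shown below. What is called first, only, known or untested is meant among the compounds shown, and "the series" means these compounds.

Compound 1 `COc1cccc(-n2cc(CO/N=C3\CC[C@]4(C)[C@@H](CC/C=C(\C)CC/C=C(\C)CCC=C(C)C)[C@](C)(O)CC[C@H]4C3(C)C)nn2)c1`: 22900 nM
Compound 2 `CC(C)=CCC/C(C)=C/CC/C(C)=C/CC[C@@H]1[C@@]2(C)CC/C(=N\OCc3cn(-c4cccc(Br)c4)nn3)C(C)(C)[C@@H]2CC[C@@]1(C)O`: 15700 nM
Compound 3 `CC(C)=CCC/C(C)=C/CC/C(C)=C/CC[C@@H]1[C@@]2(C)CC/C(=N\OCc3cn(-c4ccccc4C#N)nn3)C(C)(C)[C@@H]2CC[C@@]1(C)O`: 21200 nM

In a functional assay on HeLa cells (Homo sapiens) for cytotoxicity, read by MTT assay, with a stated time of 48 h (on this read-out lower numbers stand for stronger inhibition and higher numbers for weaker inhibition), compound 2 gives 15700 nM, which lies within the scatter of both other compounds. Compound 4 `CC(C)=CCC/C(C)=C/CC/C(C)=C/CC[C@@H]1[C@@]2(C)CC/C(=N\OCc3cn(-c4cccc(O)c4)nn3)C(C)(C)[C@@H]2CC[C@@]1(C)O` has hydroxy in place of bromo on an aromatic carbon. Two measured changes on the same aryl group bear on this: a 1.5-fold lower number from compound 1 to compound 2 (0.16 log units; within the scatter) with bromo replacing methoxy, and a 1.4-fold higher number from compound 2 to compound 3 (0.13 log units; within the scatter) with 2-cyanophenyl replacing 3-bromophenyl. Going by the values given here, both stay within the scatter, although no measured compound carries hydroxy. No shift beyond the scatter is therefore expected in this assay, and the estimated change is a 1.3-fold higher number from compound 2 to compound 4 (0.11 log units; within the scatter). For compound 4 the expected value is 20000 nM, with an estimated range of 10000 nM to 40000 nM.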

Compound 4, half-maximal inhibitory concentration: 13500 nM
The estimate for compound 4 lay 1.5-fold (0.17 log units) above the measured number; measured number inside the range.
By their numbers in this assay, from the lowest: compounds 4, 2, 3 and 1 (each within the scatter of the next).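

In this assay the hydroxy group, which adds a hydrogen-bond donor that bromo lacks, stays within the scatter of all three earlier aryl groups (a 1.2-fold lower number from compound 2 to compound 4 (0.07 log units; within the scatter)) (a 1.6-fold lower number from compound 3 to compound 4 (0.20 log units; within the scatter)) (a 1.7-fold lower number from compound 1 to compound 4 (0.23 log units; within the scatter)). Bromo, methoxy and hydroxy on this aromatic carbon thus give numbers that cannot be told apart in this read-out, and losing the methyl from the oxygen has no effect beyond the scatter. No measured evidence explains this. On these data alone, an amine or a carboxylic acid at this place remains open, as does whether any group here moves the number beyond the scatter.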